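Replacing the pyridin-4-yl group of compound 3

This account rests on a few compounds, and the source may have more. Where it says the series, first, only, none or still open, it means among the compounds named here.

In a functional assay on SNU-638 cells (Homo sapiens) for antiproliferative activity, read by sulforhodamine B assay, with a stated time of 72 h (a higher number here means a weaker inhibitor, a lower number a stronger inhibitor), compound 1 `CCCCS(=O)(=O)Nc1cc(-c2ccc3ncnc(NCCN(C)C)c3c2)cnc1OC` gives 480 nM and compound 2 `COc1ncc(-c2ccc3ncnc(NCCN(C)C)c3c2)cc1NS(=O)(=O)c1ccc(F)cc1` gives 1210 nM. Compound 3 `COc1ncc(-c2ccc3ncnc(NCc4ccncc4)c3c2)cc1NS(=O)(=O)c1ccc(F)cc1F` gives 6210 nM, the highest number of the three, which makes it the weakest inhibitor here.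

Compound 4 `COc1ncc(-c2ccc3ncnc(NCCN(C)C)c3c2)cc1NS(=O)(=O)c1ccc(F)cc1F` differs from compound 3 in one place, with (dimethylamino)methyl in place of pyridin-4-yl on a saturated chain carbon bound to a nitrogen on an aromatic ring.

Among the measured compounds shown here, no measured step makes this swap. The only one available is a 2.5-fold higher number from compound 1 to compound 2 (0.40 log units; beyond the scatter), where 4-fluorophenyl replaces butyl on a sulfonyl sulfur, a different place from this change, so it offers only indirect guidance. Compound 1 and compound 2 both carry the 2-(dimethylamino)ethyl that compound 4 gains, and both sit lower than compound 3. With so few compounds this is a hint and not a pattern.

A clear drop is therefore expected in this assay, and the estimated change is a 6.9-fold lower number from compound 3 to compound 4 (0.84 log units; beyond the scatter). The expected number for compound 4 is 900 nM, with an estimated range of 280 nM to 2800 nM.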

Compound 4, half-maximal inhibitory concentration: 620 nM
Beside the measured number, compound 4's estimate is 1.5-fold (0.16 log units) above it, within the range that was stated.
By their numbers in this assay, from the lowest: compounds 1, 4 and 2 (each within the scatter of the next, the first and the last beyond it); then compound 3.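

In this assay, the change on a saturated chain carbon bound to a nitrogen on an aromatic ring gives a 10-fold lower number from compound 3 to compound 4 (1.00 log units; beyond the scatter), so this swap can now be read directly instead of being inferred from compounds that differ elsewhere. With the 2-(dimethylamino)ethyl group in place, fluoro in place of hydrogen on an aromatic carbon gives a 2.0-fold lower number from compound 2 to compound 4 (0.29 log units; within the scatter), and exchanging butyl for 2,4-difluorophenyl at the sulfonyl sulfur gives a 1.3-fold higher number from compound 1 to compound 4 (0.11 log units; within the scatter), and both steps lie within the scatter, so neither can be told apart from no change. Nothing available here accounts for the size of any of these steps.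

The compounds shown leave open whether a longer chain ending in dimethylamino, or a morpholine at the end of the chain, would give a similar number. They also leave open whether the pyridin-4-yl swap would give a step of similar size with a butyl group on the sulfonyl sulfur.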